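Ring nitrogen substitution in a cytotoxicity series

This account rests on a few compounds, and the source may have more. Where it says the series, first, only, none or still open, it means among the compounds named here.

Measured compounds:
compound 1, `COc1cc(/C=C2\CN(C)C/C(=C\c3cccnc3)C2=O)cc(OC)c1`, 6910 nM
compound 2, `CN1C/C(=C\c2ccncc2)C(=O)/C(=C/c2ccccc2C(F)(F)F)C1`, 3300 nM

Of the compounds shown here, two have been read in a functional assay on HepG2 cells (Homo sapiens) for cytotoxicity, read by MTT assay, with a stated time of 24 h; on this read-out higher numbers stand for weaker inhibition and lower numbers for stronger inhibition. Compound 1 gives 6910 nM, and compound 2 gives 3300 nM. Within the data shown here, compound 2 thus stands at the lower of the two numbers, and its gap to compound 1 lies beyond the scatter; the two compounds differ in several places at once, so no single-point step links them.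

Among the measured compounds shown here, compound 3 is `O=C1/C(=C/c2ccncc2)CN(S(=O)(=O)c2ccc(Br)cc2)C/C1=C\c1ccccc1C(F)(F)F` and has not yet been read in this assay. It departs from compound 2 in one place: (4-bromophenyl)sulfonyl in place of methyl on an amine nitrogen in a ring.

For the measured compounds named here, no measured pair shows what a change of this kind does in this assay, so the expected step of a 1.7-fold lower number from compound 2 to compound 3 (0.22 log units; within the scatter) is only a rough guess, pointing toward a somewhat lower number, and a result within the scatter would not surprise. On that basis compound 3 is estimated at 2000 nM, with a range from 600 nM to 7000 nM.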

Compound 3, half-maximal inhibitory concentration: 14500 nM
Compound 3: the middle estimate sits 7.3-fold (0.86 log units) below what was measured; measured number outside the range, above it.
By their numbers in this assay, from the lowest: compound 2; then compound 1; then compound 3.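

The amine nitrogen in the ring now has its first single-place step: in this assay, (4-bromophenyl)sulfonyl in place of methyl gives a 4.4-fold higher number from compound 2 to compound 3 (0.64 log units; beyond the scatter). Inhibition at this position therefore responds to the group on the nitrogen, and on the background of compound 2 this change moves the number up, beyond the scatter. No measurement at hand bears on what lies behind this step.

This single step cannot separate the sulfonyl link from the 4-bromophenyl ring, and it speaks only for the background of compound 2. A phenylsulfonyl group without the bromine, or a benzyl or acetyl group on the same nitrogen, would help show which part of the change goes with the step.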